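This account rests on a few compounds, and the source may have more. Where it says the series, first, only, none or still open, it means among the compounds named here.

Measured so far in an assay on isolated protein for inhibition of serine/threonine-protein kinase PAK 1 (Homo sapiens), read by ADP-Glo, with a stated time of 40 min; a higher number here means a weaker inhibitor, a lower number a stronger inhibitor:

Compound 1, `O=C(NC1CCN(c2ncnc3[nH]ncc23)CC1)c1ccccc1Cl`, gives 5240 nM.
Compound 2, `O=C(NC1CCN(c2ncnc3[nH]ncc23)CC1)c1cccc(Cl)c1Cl`, gives 4170 nM.
Compound 3, `Cc1ccc(NC(=O)NC2CCN(c3ncnc4[nH]ncc34)CC2)cc1`, gives 4710 nM.

Compound 3 has the second highest of the three numbers, and its separation from the others is small: a 1.1-fold higher number from compound 2 to compound 3 (0.05 log units; within the scatter) and a 1.1-fold lower number from compound 1 to compound 3 (0.05 log units; within the scatter) both lie within the scatter. Compound 4, `O=C(Nc1ccc(C(F)(F)F)cc1)NC1CCN(c2ncnc3[nH]ncc23)CC1`, differs from compound 3 by trifluoromethyl in place of methyl on an aromatic carbon. Among the compounds with values here, no measured pair changes this methyl itself, so the nearest comparisons are the other substituent swaps on a six-membered aromatic ring of carbon only: a 1.3-fold lower number from compound 1 to compound 2 (0.10 log units; within the scatter), a chloro in place of hydrogen, and the exchanges of the whole aryl group in a 1.1-fold lower number from compound 1 to compound 3 (0.05 log units; within the scatter) and a 1.1-fold higher number from compound 2 to compound 3 (0.05 log units; within the scatter), all within the scatter. On that record the trifluoromethyl for methyl swap is expected to leave the number in this assay about where compound 3 sits, with no step beyond the scatter expected in either direction. Compound 4 is therefore estimated at 4500 nM, in the range 1500 nM to 13000 nM, which corresponds to an expected step of a 1.0-fold lower number from compound 3 to compound 4 (0.02 log units; within the scatter).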

Compound 4, half-maximal inhibitory concentration: 7150 nM
Compound 4: the middle estimate sits 1.6-fold (0.20 log units) below what was measured; low and high end bracket the measured number.
By their numbers in this assay, from the lowest: compounds 2, 3, 1 and 4 (each within the scatter of the next).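

In this assay, trifluoromethyl in place of methyl on the aromatic carbon para to a large group gives a 1.5-fold higher number from compound 3 to compound 4 (0.18 log units; within the scatter) and so adds a direct reading at this position, where a group of 4 heavy atoms replaces one of 1 heavy atom with no step beyond the scatter. With this result, all four compounds still lie within the scatter of the next when ranked by their numbers, so this swap does not separate compound 4 from the others. Nothing measured here explains the result.

On these data alone, whether an amine, a carboxylic acid or a methoxy group at this position would move the number beyond the scatter remains open. As far as these compounds go, it is also open whether a change to the shared core, rather than to this aryl group, would do so.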